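The compounds below may be only part of what the source reports. "The series", "measured", "known", "first", "only" and "open" are said of these compounds alone.

Of the compounds shown here, three that share one core have so far been tested in an ADME assay on Vero cells (Chlorocebus sabaeus) for cytotoxicity, read by neutral red uptake, tested at 12.3 ug/mL; a lower number here means a stronger effect, a higher number a weaker effect of the compound at the concentration tested. Compound 1 `O=C1CSC(c2ccc(Cl)cc2)N1CCN1CCCCC1` gives 90% in this assay, compound 2 `O=C1CSC(c2ccc(F)cc2)N1CCN1CCCCC1` gives 100%, and compound 3 `COc1ccccc1C1SCC(=O)N1CCN1CCCCC1` gives 100%. Going by the values given here, only one pair differs in a single place: a number 10 percentage points higher from compound 1 to compound 2 (within the scatter). On these numbers compound 2 stands level with compound 3 at the digits printed, and together the two are the highest of the three, while compound 1 lies furthest from compound 2, though still within the scatter.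

Compound 4 `O=C1CSC(c2ccc(O)cc2)N1CCN1CCCCC1` has not yet been measured in this assay. Its structure differs from compound 2 in one place: hydroxy in place of fluoro on an aromatic carbon.

Among the compounds with values here, the only measured step that bears on this change is the swap of one halogen for another from compound 1 to compound 2, which stayed within the scatter. Within the data shown here, no measured pair shows what a hydroxy group, or any group carrying a hydrogen-bond donor, does at this place, so the expectation rests on the observation that every compound so far sits near the top of the range in this assay. A step of a number 5 percentage points lower from compound 2 to compound 4 (within the scatter) is therefore expected, which is none beyond the scatter. For compound 4 the estimated value in this assay is 95%, within a range from 80% to 100%.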

Compound 4, a percentage reported as activity, at one concentration (the size of the read-out at that concentration, not a potency): 100%
For compound 4 the middle estimate is 5 percentage points below the measured one, and the stated range covers the measured number.
By their numbers in this assay, from the lowest: compounds 1, 2, 3 and 4 (each within the scatter of the next).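

In this assay, the step of no change at the digits printed from compound 2 to compound 4 (within the scatter) is the only measured case of a group with a hydrogen-bond donor on this aromatic carbon, para to a large group, so the change from 4-fluorophenyl to 4-hydroxyphenyl now has a direct reading rather than a guess. Measured against the chloro compound, the step of a number 10 percentage points higher from compound 1 to compound 4 (within the scatter) also stays within the scatter, so at this one place fluoro, chloro and hydroxy cannot be told apart in this read-out, and the earlier halogen swap alone could not show that this holds for a group other than a halogen. Nothing measured here explains why these swaps leave the read-out within the scatter.

On these data alone, all of this rests on three small groups, each a single heavy atom at this place, and on numbers that all lie close together, so the reach of this tolerance remains unknown. As far as these compounds go, whether an amine, a carboxylic acid or a longer chain such as butoxy on the same carbon would also stay within the scatter, or would move the number well away from these values, remains open.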